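From chloro to fluoro: expectation for compound 3

This account rests on a few compounds, and the source may have more. Where it says the series, first, only, none or still open, it means among the compounds named here.

In a functional assay on HCT-116 cells (Homo sapiens) for inhibition, read by colorimetric assay, with a stated time of 3 days (on this read-out lower numbers stand for stronger inhibition and higher numbers for weaker inhibition), compound 1 (`O=C(CCCCCCNC(=O)C(O)(O)C(F)(F)F)Nc1ccncc1`) gives 6670 nM and compound 2 (`O=C(CCCCCCNC(=O)C(O)(O)C(F)(F)F)Nc1ccc(Cl)cc1`) gives 4230 nM. With only these two numbers, compound 2 stands within the scatter of compound 1, so neither can be ranked.

Compound 3 (`O=C(CCCCCCNC(=O)C(O)(O)C(F)(F)F)Nc1ccc(F)cc1`) has not yet been measured. It carries fluoro in place of chloro on an aromatic carbon of a six-membered aromatic ring of carbon only, para to a large group: fluoro in place of chloro on an aromatic carbon.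

Among the measured compounds shown here, one measured step bears on this change, and only indirectly: a 1.6-fold lower number from compound 1 to compound 2 (0.20 log units; within the scatter). That step puts 4-chlorophenyl in place of pyridin-4-yl on an amide-type nitrogen, so it alters the same end of the molecule. For the measured compounds named here, no measured pair exchanges one halogen for another, so the size of such a swap is unknown. Going by the values given here, the single step available offers no reason to expect a shift in either direction, and no step beyond the scatter is anticipated in this assay.

The expected step is a 1.1-fold higher number from compound 2 to compound 3 (0.03 log units; within the scatter).

For compound 3 the estimated value is 4500 nM, with an expected range of 2000 nM to 10000 nM.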

Compound 3, half-maximal inhibitory concentration: 7570 nM
Compound 3: the middle estimate sits 1.7-fold (0.23 log units) below what was measured; measured number inside the range.
By their numbers in this assay, from the lowest: compounds 2, 1 and 3 (each within the scatter of the next).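

Working notes on the halogen swap: in this assay the first exchange of one halogen for another at this position gives a 1.8-fold higher number from compound 2 to compound 3 (0.25 log units; within the scatter) and so stays within the scatter, which means that chloro and fluoro on this aromatic carbon, para to a large group, cannot be told apart. The remaining new comparison gives a 1.1-fold higher number from compound 1 to compound 3 (0.05 log units; within the scatter) and is also within the scatter, so 4-fluorophenyl and pyridin-4-yl on the amide-type nitrogen cannot be separated either, just as 4-chlorophenyl and pyridin-4-yl could not be. With all three steps now within the scatter, these three end groups form a set that cannot be ranked in this cell read-out, and no independent measurement is available to help interpret the small differences among them.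

On these data alone, what remains open is whether a group of another kind on the same aromatic carbon, such as methoxy, an amine or a carboxylic acid, would give a step beyond the scatter. As far as these compounds go, it is equally open how a shorter or longer chain in the shared core would read, since all three compounds carry the same chain.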